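The compounds below may be only part of what the source reports. "The series", "measured", "known", "first", "only" and "open" are said of these compounds alone.

Measured in an assay on RBL-1 cells for inhibition of Polyunsaturated fatty acid 5-lipoxygenase (Rattus norvegicus); on this read-out higher numbers stand for weaker inhibition and lower numbers for stronger inhibition:
Compound 1 `CN(O)/C=C\C(=O)c1ccc(Cl)cc1` — 550 nM
Compound 2 `O=C(/C=C\N(O)Cc1ccc(-c2ccccc2)cc1)c1ccc(F)cc1` — 3000 nM
Compound 3 `O=C(/C=C\N(O)Cc1ccccc1)c1ccc(Cl)c(Cl)c1` — 610 nM

Compound 2 gives the highest number of the three. Its nearest neighbour is compound 3, whose number in this assay is lower by an amount beyond the scatter, and compound 1 sits lower still, also beyond the scatter. Compound 4 `O=C(/C=C\N(O)Cc1ccc(-c2ccccc2)cc1)c1cccs1` differs from compound 2 in one place: thiophen-2-yl in place of 4-fluorophenyl on a carbonyl carbon. Among the measured compounds shown here, no pair among the measured compounds isolates this exchange, so its effect in this assay is unknown from these data. The change expected is small, a 1.2-fold higher number from compound 2 to compound 4 (0.07 log units; within the scatter), with no preferred direction beyond the scatter. For compound 4 in this assay the estimate is 3500 nM, within a range from 1200 nM to 10000 nM.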

Compound 4, half-maximal inhibitory concentration: > 25000 nM
Compound 4: a limit, no number (the forecaster's own chance of this, stated with the estimate: 5%); middle value at least 7.1-fold (0.85 log units) away from the limit.
By their numbers in this assay, from the lowest: compounds 1 and 3 (each within the scatter of the next); then compound 2. At a limit, above all of these: compound 4.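

Compound 4 gives > 25000 nM in this assay, which is a limit of the assay and not a number: the limit of > 25000 nM in this assay, at which 1 of the 4 values shown sits. Thiophen-2-yl in place of 4-fluorophenyl on a carbonyl carbon gives an at least 8.3-fold higher number from compound 2 to compound 4 (0.92 log units; beyond the scatter), so in this one pair the place is sensitive to the exchange. The earlier compounds shown here all carry a halogen-bearing phenyl here, and no pair of them varied this place alone.

As far as these compounds go, the full size of the step stays open, since only its lower bound can be read. Plain phenyl or thiophen-3-yl at this place would show whether the change follows the thiophene ring or the missing fluorine.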